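This account rests on a few compounds, and the source may have more. Where it says the series, first, only, none or still open, it means among the compounds named here.

Measured so far:
compound 1, `N=C(N)NCCC[C@@H](NC(=O)c1cc2ccccc2cn1)C(=O)NCc1ccc(C(F)(F)F)cc1`: 1810 nM
compound 2, `N=C(N)NCCC[C@@H](NC(=O)c1cc2cc(F)ccc2[nH]1)C(=O)NCc1ccc(C(F)(F)F)cc1`: 25 nM

Among the compounds with values here, in a functional assay on HEK293 cells for antagonist activity at melanin-concentrating hormone receptor 1 (Homo sapiens) (on this read-out lower numbers stand for stronger inhibition and higher numbers for weaker inhibition), compound 1 stands at the higher of the two numbers; its only neighbour is compound 2, reached by a 72-fold lower number from compound 1 to compound 2 (1.86 log units; beyond the scatter). Compound 3, `N=C(N)NCCC[C@@H](NC(=O)c1ccc2ccccc2n1)C(=O)NCc1ccc(C(F)(F)F)cc1`, is unmeasured. The change is quinolin-2-yl in place of isoquinolin-3-yl on a carbonyl carbon. Within the data shown here, the one measured step, from compound 1 to compound 2, is a different exchange at the same carbonyl carbon and shows only that this position can move the number strongly; no measured step matches the present exchange. For compound 3 the expected step is a 1.2-fold lower number from compound 1 to compound 3 (0.08 log units; within the scatter), not clearly beyond the scatter. Compound 3 is estimated at 1500 nM, ranging from 400 nM to 6000 nM.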

Compound 3, half-maximal inhibitory concentration: 904 nM
Compound 3: the middle estimate sits 1.7-fold (0.22 log units) above what was measured; the measured number falls inside the stated range.
By their numbers in this assay, from the lowest: compound 2; then compounds 3 and 1 (each within the scatter of the next).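

In this assay, quinolin-2-yl in place of isoquinolin-3-yl on the carbonyl carbon gives a 2.0-fold lower number from compound 1 to compound 3 (0.30 log units; within the scatter) and so, with the same atoms joined differently, does not separate the two on this read-out. The 5-fluoro-1H-indol-2-yl group stands apart from quinolin-2-yl, with a 36-fold higher number from compound 2 to compound 3 (1.56 log units; beyond the scatter) on that exchange. No further data on this result are at hand.

The compounds shown leave open what an unsubstituted 1H-indol-2-yl or a plain phenyl would give on this carbonyl carbon. Whether the fluorine or the indole ring accounts for the gap therefore remains unresolved.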